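A few compounds are considered here, and "the series" means these few. Any claim that something is new, unique, unknown or untested is made for them only; others in the source may bear on it.

Compounds measured:
Compound 1 `COc1cc(Cc2cnc(/N=C3\C(=O)N(CN4CCC(C)CC4)c4ccc(Cl)cc43)nc2N)cc(OC)c1OC`: 67.4 ug/mL
Compound 2 `COc1cc(Cc2cnc(/N=C3\C(=O)N(CN4CCN(C)CC4)c4ccc(Cl)cc43)nc2N)cc(OC)c1OC`: 80.7 ug/mL
Compound 3 `COc1cc(Cc2cnc(/N=C3\C(=O)N(CN4CCN(c5ccccn5)CC4)c4ccc(Cl)cc43)nc2N)cc(OC)c1OC`: 39.2 ug/mL

In an ADME assay on MT4 cells (Homo sapiens) for cytotoxicity, read by MTT assay, with a stated time of 5 days (on this read-out higher numbers stand for lower toxicity in this test and lower numbers for higher toxicity in this test), compound 3 gives the lowest of the three numbers, yet only its gap to compound 2 counts: a 2.1-fold lower number from compound 2 to compound 3 (0.31 log units; beyond the scatter). Against compound 1 the gap is smaller, a 1.7-fold lower number from compound 1 to compound 3 (0.24 log units; within the scatter), and compound 1 and compound 2 sit close together, a 1.2-fold higher number from compound 1 to compound 2 (0.08 log units; within the scatter).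

Compound 4 `CCN(CC)CN1C(=O)/C(=N\c2ncc(Cc3cc(OC)c(OC)c(OC)c3)c(N)n2)c2cc(Cl)ccc21` has not yet been tested. Its change from compound 3 is diethylamino in place of 4-(pyridin-2-yl)piperazin-1-yl on a saturated chain carbon bound to an amide-type nitrogen in a ring. The two steps that bear on it both swap the group on that carbon. From compound 1 to compound 3 the swap of a ring for a ring left the number within the scatter; from compound 2 to compound 3 the swap of methyl for pyridin-2-yl gave a modest lower number. Compound 4 removes the pyridin-2-yl ring altogether and opens the ring to a chain, a change of a size not seen among the three measured compounds. Among the compounds with values here, the steps so far suggest that losing the pyridyl group should move the number back toward those of compound 1 and compound 2, so a modest higher number is expected, a 1.6-fold higher number from compound 3 to compound 4 (0.20 log units; within the scatter). Compound 4 is therefore estimated at 62 ug/mL in this assay, with a range from 32 ug/mL to 120 ug/mL.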

Compound 4, half-maximal cytotoxic concentration: 79.1 ug/mL
Estimate against measurement, compound 4: 1.3-fold (0.11 log units) below; the range from low to high includes it.
By their numbers in this assay, from the lowest: compounds 3, 1, 4 and 2 (each within the scatter of the next, the first and the last beyond it).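

In this assay the open diethylamino group, which has no ring, cannot be told apart from the two ring-bearing groups on the saturated chain carbon, with a 1.0-fold lower number from compound 2 to compound 4 (0.01 log units; within the scatter) and a 1.2-fold higher number from compound 1 to compound 4 (0.07 log units; within the scatter) as the readings, so at this position a ring in the amine is not needed for a number in the range of those two compounds. Even the large exchange of 4-(pyridin-2-yl)piperazin-1-yl, with 12 heavy atoms, for diethylamino, with 5, gives a 2.0-fold higher number from compound 3 to compound 4 (0.30 log units; within the scatter) and stays just inside the scatter, leaving a 2.1-fold lower number from compound 2 to compound 3 (0.31 log units; beyond the scatter) as the only step here that lies beyond it. Nothing shown gives a reason for these numbers.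

Only compound 3 carries the pyridin-2-yl ring, so the compounds shown leave open whether another aryl group on the piperazine, such as phenyl, would go with the same lower number. They also leave open whether a longer chain such as dipropylamino, a morpholin-4-yl ring or a carboxylic acid on the amine would stay in the same range.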